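Removing one methyl from the chain of compound 3

The source may report more compounds than this note shows. Statements on the series, on what has been measured and on what is new or still open speak of the compounds shown alone.

Three compounds share a core and differ in a chain on it and in a group on the aryl ring. Compound 1 `COCc1nc2nc(C)cc(Nc3ccc(C(F)(F)F)cc3)n2n1` gives 75.6% in an ADME assay on a cell-free system (plasma, Homo sapiens) for protein binding; compound 2 `CCc1nc2nc(C)cc(Nc3ccc(C(F)(F)F)cc3)n2n1` gives 87.5%; compound 3 `Cc1cc(Nc2ccc(Cl)cc2)n2nc(C(C)C)nc2n1` gives 84.9%. Compound 3 holds the second highest of the three unbound fractions: compound 2 lies nearest, and compound 1 furthest, both within the scatter. Within the data shown here, the only counted step, a 2.0-fold lower unbound fraction from compound 1 to compound 2 (0.29 log units; within the scatter), also concerns the chain on the core and stayed within the scatter.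

Compound 4 `CCc1nc2nc(C)cc(Nc3ccc(Cl)cc3)n2n1` is not yet measured. It differs from compound 3 by hydrogen in place of methyl on a saturated chain carbon bound to an aromatic carbon and a saturated chain carbon. Among the measured compounds shown here, the change is small, one carbon leaves, and the one comparable step on this chain was within the scatter, so compound 4 is expected to show at most a slight rise in the unbound fraction, a 1.3-fold higher unbound fraction from compound 3 to compound 4 (0.10 log units; within the scatter), not clearly beyond the scatter. Compound 4 is therefore estimated at 81%, with a range from 69% to 89%.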

Compound 4, plasma protein binding in the plasma assay: 86.1%
Estimate against measurement, compound 4: 1.4-fold (0.14 log units) (unbound fraction) above; low and high end bracket the measured number.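

In the plasma assay, the cut from isopropyl to ethyl gives a 1.1-fold lower unbound fraction from compound 3 to compound 4 (0.04 log units; within the scatter), and the group on the aryl ring, until now changed only together with the chain, gets a step of its own, a 1.1-fold higher unbound fraction from compound 2 to compound 4 (0.05 log units; within the scatter). In a physicochemical assay for lipophilicity, at pH 7.4 (on this read-out lower numbers stand for lower lipophilicity and higher numbers for higher lipophilicity), compound 3 gives 3.2 and compound 4 gives 2.8, which is a number 0.40 log units lower from compound 3 to compound 4 (beyond the scatter). Removing this one methyl thus lowers lipophilicity measurably, while the reading in the plasma assay stays within the scatter: the measured distribution coefficient of compound 3, 3.2, and of compound 4, 2.8, a number 0.40 log units lower (beyond the scatter)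

The compounds shown leave open whether an amine or a carboxylic acid on this chain carbon, or a longer chain, would shift the reading in the plasma assay beyond the scatter. They also leave open whether a group other than chloro or trifluoromethyl on the aryl ring, such as a nitrile, would do so.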